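The source may report more compounds than this note shows. Statements on the series, on what has been measured and on what is new or still open speak of the compounds shown alone.

Compound 1, `CC(C)(C)CC[C@H](c1ccc(C(=O)NCc2nn[nH]n2)cc1)N1C(=O)C(c2cncc(Cl)c2)=N[C@]12CC[C@@H](C(C)(C)C)CC2`, is the point of departure. In a functional assay on CHO cells for antagonist activity at Glucagon receptor (Homo sapiens), read by cAMP accumulation, with stated times of 30 min and 45 min (on this read-out lower numbers stand for stronger inhibition and higher numbers for weaker inhibition), compound 1 gives 480 nM, the second highest of the three numbers recorded so far. Its nearest neighbour is compound 3, `CC(C)(C)[C@H]1CC[C@]2(CC1)N=C(c1ccc(Cl)cc1)C(=O)N2Cc1ccc(C(=O)NCCC(=O)O)cc1`, which in this assay gives 1400 nM, a higher number that lies beyond the scatter. Furthest from it is compound 2, `CC1(CC[C@H](c2ccc(C(=O)NCc3nn[nH]n3)cc2)N2C(=O)C(c3cc(Cl)cc(Cl)c3)=N[C@]23CC[C@@H](C(C)(C)C)CC3)CC1`, which in this assay gives 100 nM, a lower number that also lies beyond the scatter; compound 2 and compound 1 differ in more than one place, so their two values alone do not single out any one change.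

Compound 4, `CC(C)(C)CC[C@H](c1ccc(C(=O)NCc2nn[nH]n2)cc1)N1C(=O)C(c2ccc(C(F)(F)F)cc2)=N[C@]12CC[C@@H](C(C)(C)C)CC2`, is reached from compound 1 by a single change: 4-(trifluoromethyl)phenyl in place of 5-chloropyridin-3-yl on a carbon with a double bond to nitrogen. Among the compounds with values here, no measured pair shows this particular change, so there is no step to lean on. The replacement of one aromatic ring by another on the same carbon is expected to give a modest shift in this assay, toward a lower number, but not one clearly beyond the scatter. Compound 4 is accordingly estimated at 300 nM, within a range of 80 nM to 1100 nM, so that the expected step is a 1.6-fold lower number from compound 1 to compound 4 (0.20 log units; within the scatter).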

Compound 4, half-maximal inhibitory concentration: 160 nM
Compound 4: middle estimate off by 1.9-fold (0.27 log units), on the high side, and the stated range covers the measured number.
By their numbers in this assay, from the lowest: compounds 2 and 4 (each within the scatter of the next); then compound 1; then compound 3.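

Within the data shown here, at the carbon with a double bond to nitrogen, in this assay the exchange of 5-chloropyridin-3-yl for 4-(trifluoromethyl)phenyl gives a 3.0-fold lower number from compound 1 to compound 4 (0.48 log units; beyond the scatter) and is the first change here that can be read on its own, as the earlier compounds differ in more than one place. With the rest of compound 1 held fixed, the number therefore depends on which aromatic ring this carbon carries. Nothing given here explains the size of this step.

Going by these compounds, this single step swaps the ring nitrogen, the chlorine and the trifluoromethyl group together, so it remains open whether a plain phenyl ring or a phenyl ring bearing chlorine would lie nearer compound 1 or compound 4. Also open, on these data alone, is whether the same exchange would give a similar step on the core of compound 2.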